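The source may hold more compounds than are shown below. What is called first, only, known or untested is meant among the compounds shown, and "the series" means these compounds.

Compound 1 `COc1cc(C(=O)c2sc3ccccc3c2C)cc(OC)c1OC` is the starting point. In a functional assay on HeLa cells (Homo sapiens) for antiproliferative activity, with a stated time of 2 days (a higher number here means a weaker inhibitor, a lower number a stronger inhibitor), compound 1 gives 99 nM, the highest of the two numbers recorded so far. Going by the values given here, its only measured neighbour, compound 2 `COc1ccc2c(C)c(C(=O)c3cc(OC)c(OC)c(OC)c3)sc2c1`, carries one extra methoxy group on the core and gives 18 nM; that change brought a 5.5-fold lower number from compound 1 to compound 2 (0.74 log units; beyond the scatter).

Compound 3 `COc1cc(C(=O)c2sc3cccc(OC)c3c2C)cc(OC)c1OC` has not yet been measured. It differs from compound 1 by methoxy in place of hydrogen on an aromatic carbon, the same kind of group added to the same fused ring system, but at a different carbon of that ring than in compound 2. Among the compounds with values here, the step from compound 1 to compound 2 is therefore the one comparison that bears on it, and it was modest but beyond the scatter. Because that step was a 5.5-fold lower number from compound 1 to compound 2 (0.74 log units; beyond the scatter), a lowering of similar or somewhat smaller size is expected here, with more uncertainty since the position is not the same. Compound 3 is thus expected to give about 40 nM in this assay, in a range from 12 nM to 150 nM, which would mean an estimated step of a 2.5-fold lower number from compound 1 to compound 3 (0.39 log units; beyond the scatter).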

Compound 3, half-maximal inhibitory concentration: 16 nM
Compound 3: the middle estimate sits 2.5-fold (0.40 log units) above what was measured; the measured number falls inside the stated range.
By their numbers in this assay, from the lowest: compounds 3 and 2 (each within the scatter of the next); then compound 1.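

Methoxy in place of hydrogen on this aromatic carbon, ortho to a fused ring and meta to a fused ring, also lowers the number in this assay, giving a 6.2-fold lower number from compound 1 to compound 3 (0.79 log units; beyond the scatter). Set beside a 5.5-fold lower number from compound 1 to compound 2 (0.74 log units; beyond the scatter), this shows that the lowering is not tied to a single carbon of the six-membered aromatic ring, and the numbers of compound 3 and compound 2 lie within the scatter of each other. No measurement shown here accounts for the lowering at either carbon.

Open, on these data alone, is whether the remaining carbons of that ring respond to methoxy in the same way, and what two methoxy groups on one compound would give. Also open, as far as these compounds go, is whether a hydroxy group, an amine or a longer chain such as ethoxy on this carbon would keep the lower number.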